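A few compounds are considered here, and "the series" means these few. Any claim that something is new, unique, unknown or untested is made for them only; others in the source may bear on it.

Measured so far:
compound 1, `CC(=O)O[C@@H](C)[C@@H](/C=C/[C@@H]1O[C@@H]1[C@H]1CC=CC(=O)O1)OC(C)=O`: 0.4 ug/mL
compound 2, `CCCC[C@H](O)/C=C\[C@@H]1OC(=O)C=C[C@@H]1OC(C)=O`: 0.1 ug/mL
compound 3, `CCCC[C@H](OC(C)=O)[C@@H](O)[C@H](O)[C@@H]1OC(=O)C=C[C@@H]1OC(C)=O`: 0.5 ug/mL

All three numbers come from a functional assay on P388 cells (Mus musculus) for cytotoxicity, read by sulforhodamine B assay, with a stated time of 48 h; on this read-out higher numbers stand for an effect only at larger amounts of compound and lower numbers for an effect already at smaller amounts. Compound 2 gives the lowest number of the three, meaning its effect is seen at the smallest amount of compound. Its gap to compound 1 and its gap to compound 3 both lie beyond the usual scatter of repeated measurements, so on these numbers compound 2 stands apart as the most potent of the measured set.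

The next compound, compound 4, `CCCC[C@@H](/C=C\[C@@H]1OC(=O)C=C[C@@H]1OC(C)=O)OC(C)=O`, is not yet measured in this assay. It keeps the whole frame of compound 2 and changes one thing: acetyl in place of hydrogen on an oxygen on a saturated carbon. In words of the same kind, a free hydroxy becomes an acetoxy on the chain bearing the butyl group.

Among the compounds with values here, no measured pair shows this exact change, so its effect cannot be read off directly. Compound 1 and compound 3, which carry an acetyl on the corresponding chain oxygen, give higher numbers than compound 2, but they differ from it in other places as well, so they are only a loose hint. The expectation for compound 4 is therefore a small step toward a higher number in this assay, of a size that may well stay within the scatter, written as a 2.0-fold higher number from compound 2 to compound 4 (0.30 log units; within the scatter). Compound 4 is accordingly estimated at 0.2 ug/mL, with a likely range from 0.05 ug/mL to 0.8 ug/mL.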

Compound 4, concentration for half-maximal effect: 0.9 ug/mL
Compound 4: middle estimate off by 4.5-fold (0.65 log units), on the low side; the whole stated range lies below it.
By their numbers in this assay, from the lowest: compound 2; then compounds 1, 3 and 4 (each within the scatter of the next, the first and the last beyond it).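

Within the data shown here, exchanging the free hydroxy for an acetoxy on this chain is the only change here that can be read on its own, and in this assay it gives a 9.0-fold higher number from compound 2 to compound 4 (0.95 log units; beyond the scatter). This oxygen on a saturated carbon is therefore a place where the change matters: with everything else held the same, an acetyl in place of the hydrogen means that much more compound is needed for the same effect. Nothing available here explains this step.

It remains open whether any group on this oxygen would raise the number as much, or whether this is particular to the acetyl, since neither a methyl ether nor a longer ester such as butanoyl appears among the compounds shown. From the compounds shown here alone, it is also open whether turning the other acetoxy of compound 2 into a free hydroxy would move the number at all.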